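Shortening a Side Chain on a Shared Core

The source may report more compounds than this note shows. Statements on the series, on what has been measured and on what is new or still open speak of the compounds shown alone.

Measured compounds:
Compound 1 `CCC(C)c1cc(C=O)cc2cc(C(C)=O)c(=O)oc12` gives "not active" (no number reported) in a functional assay on NIH3T3 cells (Mus musculus) for cytotoxicity, read by sulforhodamine B assay, with a stated time of 48 h; on this read-out higher numbers stand for weaker inhibition and lower numbers for stronger inhibition.
Compound 2 `CCOC(=O)c1cc2cc(/C=C/C(=O)c3ccccc3)cc(C(C)CC)c2oc1=O` gives "not active" (no number reported) in this assay.
Compound 3 `CCOC(=O)c1cc2cc(/C=C/C(=O)c3ccc(Cl)cc3)cc(C(C)CC)c2oc1=O` gives 38400 nM in this assay.

All three compounds share one core and were tested for their ability to kill mouse fibroblast cells. For compound 1 and compound 2 no number was reported at all; both were simply recorded as inactive in this assay. Only compound 3 produced a measurable half-maximal inhibitory concentration, and that value is weak. So compound 2 stands among the compounds for which this read-out gave no usable number; with two such entries, no ranking among them is possible.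

Compound 4 `CCOC(=O)c1cc2cc(C=O)cc(C(C)CC)c2oc1=O` has not yet been tested. It differs from compound 2 in a single place: formyl in place of 2-benzoylethenyl on an aromatic carbon. The long arm carrying a benzoyl group and a second ring is cut back to a small formyl group. Within the data shown here, compound 1 also carries a formyl group and was recorded as inactive, and compound 2 itself gave no number, so there is no measured step to lean on. The expectation is that no step beyond the scatter appears, and that compound 4 most likely stays inactive, with a half-maximal inhibitory concentration estimated near 100000 nM (range 30000 nM to 300000 nM) if a number is obtained at all.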

Compound 4, half-maximal inhibitory concentration: "not active" (no number reported)
The entry for compound 4 holds no number, and the estimate cannot be compared.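

In this assay compound 2 gives "not active" (no number reported) and compound 4 gives "not active" (no number reported), so no step can be read between these two compounds. No measurement shown here offers an explanation for this result. From the compounds shown here alone, whether replacing 2-benzoylethenyl with formyl changes the activity against these cells at all remains open.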